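This account rests on a few compounds, and the source may have more. Where it says the series, first, only, none or still open, it means among the compounds named here.

Series notes. Compound 1 `COc1cc(N(CC(C)C)c2cccc(C(F)(F)F)c2)cnc1C(=O)[C@H]1C[C@@H]1C(=O)O` and compound 2 `CCN(c1cccc(C(F)(F)F)c1)c1cnc(C(=O)[C@H]2C[C@@H]2C(=O)O)c(OC)c1` share one core and differ only in the chain on the saturated carbon bound to a nitrogen on an aromatic ring. In an assay on isolated protein for inhibition of leukotriene C4 synthase (Homo sapiens), read by LC-MS, with stated times of 45 min and 20 min (a higher number here means a weaker inhibitor, a lower number a stronger inhibitor), compound 1 gives 20.6 nM, and in this assay compound 2 gives 113 nM. For the measured compounds named here, the single step in hand, a 5.5-fold higher number from compound 1 to compound 2 (0.74 log units; beyond the scatter), is the methyl-for-isopropyl exchange at that carbon; it shows that shortening this chain weakens the inhibitor. Compound 2 thus stands as the weaker of the two measured compounds, separated from compound 1 by a gap beyond the scatter.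

Compound 3 `COc1cc(N(Cc2ccc(F)cc2)c2cccc(C(F)(F)F)c2)cnc1C(=O)[C@H]1C[C@@H]1C(=O)O` is not yet measured. Relative to compound 2 the change is 4-fluorophenyl in place of methyl on a saturated chain carbon bound to a nitrogen on an aromatic ring: a 4-fluorophenyl enters where the methyl sat, so the ethyl becomes 4-fluorobenzyl. Going by the values given here, only the step from compound 1 to compound 2 bears on this, and it ran the other way, the smaller chain giving the higher number. A larger group on this carbon is therefore expected to lower the number in this assay, with a step of about a 4.5-fold lower number from compound 2 to compound 3 (0.66 log units; beyond the scatter) expected. For compound 3 the estimate in this assay is 25 nM, with a range from 8 nM to 80 nM.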

Compound 3, half-maximal inhibitory concentration: 157 nM
Estimate against measurement, compound 3: 6.3-fold (0.80 log units) below, and the stated range ends below it.
By their numbers in this assay, from the lowest: compound 1; then compounds 2 and 3 (each within the scatter of the next).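

In this assay, the exchange of methyl for 4-fluorophenyl at this carbon leaves the number within the scatter (a 1.4-fold higher number from compound 2 to compound 3 (0.14 log units; within the scatter)), so ethyl and 4-fluorobenzyl on the nitrogen cannot be told apart here, and a larger group on this carbon does not of itself lower the number. The isopropyl of compound 1 now stands apart from both exchanges, since the gap to the 4-fluorophenyl group (a 7.6-fold higher number from compound 1 to compound 3 (0.88 log units; beyond the scatter)) lies beyond the scatter, as does the gap to methyl (a 5.5-fold higher number from compound 1 to compound 2 (0.74 log units; beyond the scatter)); among these three compounds the lower number therefore goes with the isopropyl alone, and compound 3 goes against any reading of the first step as a simple trend with the size of the group. Nothing at hand bears on why isopropyl at this carbon differs from the other two groups.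

On these data alone, it remains open whether other saturated groups at this carbon, such as cyclopropyl, tert-butyl or a longer chain, would share the number of compound 1 or fall with compounds 2 and 3. As far as these compounds go, it is also open whether a plain phenyl or a pyridine ring would read differently from the 4-fluorophenyl group in compound 3.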